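Trimming a Methyl from the Hydroxyalkyl Ether Side Chain

A few compounds are considered here, and "the series" means these few. Any claim that something is new, unique, unknown or untested is made for them only; others in the source may bear on it.

Of the compounds shown here, three built on a shared core have been tested in a functional assay on HeLa cells (Homo sapiens) for cytotoxicity, read by MTT assay; a higher number here means a weaker inhibitor, a lower number a stronger inhibitor. Compound 1 `CC(C)=CC[C@@H](OC[C@H](C)O)C1=CC(=O)c2c(O)ccc(O)c2C1=O` gives 40300 nM in this assay. Compound 2 `CCCC(O)CC(=O)O[C@H](CC=C(C)C)C1=CC(=O)c2c(O)ccc(O)c2C1=O` gives 59300 nM in this assay. For compound 3 `CC(C)=CC[C@@H](OC(=O)C1CCCCO1)C1=CC(=O)c2c(O)ccc(O)c2C1=O`, this assay returns only a limit, > 100000 nM, not a number. Among the numbers shown, compound 1 holds the lowest, with compound 2 nearest: a 1.5-fold higher number from compound 1 to compound 2 (0.17 log units; within the scatter). The step of an at least 2.4-fold higher number from compound 1 to compound 3 (0.39 log units; beyond the scatter) runs into the limit (the limit of > 100000 nM in this assay, at which 1 of the 3 values shown sits), and the step of an at least 1.6-fold higher number from compound 2 to compound 3 (0.22 log units; that floor lies within the scatter) does so as well.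

Compound 4 `CC(C)=CC[C@@H](OCCO)C1=CC(=O)c2c(O)ccc(O)c2C1=O` has not yet been measured. It differs from compound 1 by hydrogen in place of methyl on a saturated chain carbon bound to an oxygen on a saturated carbon and a saturated chain carbon. Among the compounds with values here, no measured step tests a change this small: the steps of a 1.5-fold higher number from compound 1 to compound 2 (0.17 log units; within the scatter) and an at least 2.4-fold higher number from compound 1 to compound 3 (0.39 log units; beyond the scatter) each replace the whole group on the oxygen on a saturated carbon with a carbonyl-linked group, and an at least 1.6-fold higher number from compound 2 to compound 3 (0.22 log units; that floor lies within the scatter) swaps one carbonyl-linked group for another. Removing a single methyl from the 2-hydroxypropyl chain is therefore expected to give a step of a 1.1-fold higher number from compound 1 to compound 4 (0.05 log units; within the scatter) that stays within the scatter. Compound 4 is estimated to give 45000 nM in this assay, with a likely range from 20000 nM to 100000 nM.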

Compound 4, half-maximal inhibitory concentration: 18600 nM
Beside the measured number, compound 4's estimate is 2.4-fold (0.38 log units) above it, outside the stated range (below it).
By their numbers in this assay, from the lowest: compound 4; then compounds 1 and 2 (each within the scatter of the next). At a limit, above all of these: compound 3.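

Within the data shown here, at this place, on a saturated chain carbon bound to an oxygen on a saturated carbon and a saturated chain carbon, trimming 2-hydroxypropyl to 2-hydroxyethyl removes only one methyl, yet in this assay it gives a 2.2-fold lower number from compound 1 to compound 4 (0.34 log units; beyond the scatter); the earlier steps all replaced whole groups, so they could not show that a change of this size registers here. The ether-linked compound 4 also separates clearly from a carbonyl-linked group, which compound 1 did not do within the scatter, with a 3.2-fold lower number from compound 2 to compound 4 (0.50 log units; beyond the scatter). Against the other carbonyl-linked group the step is an at least 5.3-fold lower number from compound 3 to compound 4 (0.73 log units; beyond the scatter), and it gives only a floor, as compound 3 stands at a limit and not at a number: the limit of > 100000 nM in this assay, at which 1 of the 4 values shown sits.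

The compounds shown leave open how this chain responds to other changes, such as a longer chain like 3-hydroxypropyl, or an amine or a carboxylic acid in place of the terminal hydroxyl. They also leave open what lies behind the step, since a single read-out, this assay, records the size of the change and not its cause.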